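Pyrazole amides as mGlu5 modulators: swapping the amide aryl group

This account rests on a few compounds, and the source may have more. Where it says the series, first, only, none or still open, it means among the compounds named here.

Measured compounds:
compound 1 `COc1ccc(C(=O)Nc2cc(-c3ccccc3)nn2-c2ccccc2)cc1` 54 nM
compound 2 `O=C(Nc1cc(-c2ccccc2)nn1-c1ccccc1)c1ccc([N+](=O)[O-])cc1` 10.7 nM
compound 3 `Cc1ccc(C(=O)Nc2cc(-c3ccccc3)nn2-c2ccccc2)cc1C` 20 nM

In a functional assay on cells for positive allosteric modulation of metabotropic glutamate receptor 5 (Rattus norvegicus), read by calcium flux (a higher number here means that more compound is needed for the effect, a lower number that less compound is needed), compound 3 stands second highest of the three numbers, with compound 2 the nearest and compound 1 the furthest away: the step of a 1.9-fold higher number from compound 2 to compound 3 (0.27 log units; within the scatter) lies within the scatter, while the step of a 2.7-fold lower number from compound 1 to compound 3 (0.43 log units; beyond the scatter) lies beyond it. Compound 4 `O=C(Nc1cc(-c2ccccc2)nn1-c1ccccc1)c1ccncc1` is the unmeasured neighbour of compound 3; the change is pyridin-4-yl in place of 3,4-dimethylphenyl on a carbonyl carbon. Going by the values given here, no measured pair replaces a carbon ring with a nitrogen-containing one, so no step bears directly on it. The steps of a 5.0-fold lower number from compound 1 to compound 2 (0.70 log units; beyond the scatter) and a 2.7-fold lower number from compound 1 to compound 3 (0.43 log units; beyond the scatter) show that this position tolerates modest moves in either direction. Compound 4 is therefore expected to give a somewhat higher number, estimated at 100 nM within 25 nM to 400 nM, a step of a 5.0-fold higher number from compound 3 to compound 4 (0.70 log units; beyond the scatter).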

Compound 4, half-maximal effective concentration: 2500 nM
The estimate for compound 4 lay 25-fold (1.40 log units) below the measured number; the measured number lies above the stated range.
By their numbers in this assay, from the lowest: compounds 2 and 3 (each within the scatter of the next); then compound 1; then compound 4.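

Earlier swaps at this position moved the number only modestly, but pyridin-4-yl on the carbonyl carbon gives large steps against all three substituted phenyl groups: a 130-fold higher number from compound 3 to compound 4 (2.10 log units; beyond the scatter), a 230-fold higher number from compound 2 to compound 4 (2.37 log units; beyond the scatter) and a 46-fold higher number from compound 1 to compound 4 (1.67 log units; beyond the scatter). In this assay, going by these compounds alone, this position is therefore far less forgiving of this change than the earlier compounds suggested. Nothing available gives a reason for the jump.

The compounds shown cannot separate the effect of the ring nitrogen from that of having no substituent on the ring. A plain phenyl group or a pyridin-3-yl group would help to tell these apart.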